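Replacing 2-methoxyphenyl with tert-butyl in an antiproliferative series

A few compounds are considered here, and "the series" means these few. Any claim that something is new, unique, unknown or untested is made for them only; others in the source may bear on it.

In a functional assay on MCF7 cells (Homo sapiens) for antiproliferative activity, read by MTT assay, with a stated time of 72 h (a lower number here means a stronger inhibitor, a higher number a weaker inhibitor), compound 1 (`O=C1O[C@H]([C@@H](O)Cn2cc(-c3cccc(O)c3)nn2)C(OCc2ccccc2)=C1OCc1ccccc1`) gives 51800 nM. Compound 2 (`COc1ccccc1-c1cn(C[C@H](O)[C@H]2OC(=O)C(OCc3ccccc3)=C2OCc2ccccc2)nn1`) gives only a limit of the assay, > 100000 nM, so it has no exact number. Compound 3 (`CC(C)(C)c1cn(C[C@H](O)[C@H]2OC(=O)C(OCc3ccccc3)=C2OCc2ccccc2)nn1`) carries tert-butyl in place of 2-methoxyphenyl on an aromatic carbon. Within the data shown here, the one measured step bearing on this change is an at least 1.9-fold higher number from compound 1 to compound 2 (0.28 log units; that floor lies within the scatter), also a swap on an aromatic carbon. On that slim evidence, an at least 1.1-fold lower number from compound 2 to compound 3 (0.04 log units; that floor lies within the scatter) is expected, with no change beyond the scatter in this assay. Compound 3 is estimated at 90000 nM, with an expected range of 40000 nM to 200000 nM.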

Compound 3, half-maximal inhibitory concentration: 730 nM
Estimate against measurement, compound 3: 120-fold (2.09 log units) above; the measured number lies below the stated range.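

In this assay, the group on this carbon of the triazole-type ring, the five-membered aromatic ring with 3 nitrogen, turns out to matter greatly: tert-butyl gives an at least 130-fold lower number from compound 2 to compound 3 (2.13 log units; beyond the scatter) and a 71-fold lower number from compound 1 to compound 3 (1.85 log units; beyond the scatter). An aromatic ring at this position is therefore not required for activity in this series, and of the three groups shown, the one without a ring gives the lowest number. The first of these steps is only a floor, since compound 2 is held by a limit: the limit of > 100000 nM in this assay, at which 1 of the 3 values shown sits.

On these data alone, it remains open whether the gain comes from losing the aromatic ring or is particular to tert-butyl. As far as these compounds go, how isopropyl, cyclohexyl or an amine would fare at this position also stays open.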